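From compound 1 to compound 3: adding 2-oxopyrrolidin-1-yl

The source may report more compounds than this note shows. Statements on the series, on what has been measured and on what is new or still open speak of the compounds shown alone.

Values measured so far in a functional assay on A549 cells (Homo sapiens) for inhibition, read by sulforhodamine B assay, with a stated time of 74 h (on this read-out higher numbers stand for weaker inhibition and lower numbers for stronger inhibition), are these:
Compound 1 `O=C1C=CC2(C=C1)OCC(=O)N2S(=O)(=O)c1ccccc1` gives a limit (> 10000 nM)
Compound 2 `N#Cc1cccc(S(=O)(=O)N2C(=O)COC23C=CC(=O)C=C3)c1` gives a number (1910 nM)

Compound 1 has only a limit of the assay (> 10000 nM) and no number. Compound 3 `O=C1C=CC2(C=C1)OCC(=O)N2S(=O)(=O)c1ccc(N2CCCC2=O)cc1` has not yet been measured. Its difference from compound 1 (2-oxopyrrolidin-1-yl in place of hydrogen on an aromatic carbon) is 2-oxopyrrolidin-1-yl in place of hydrogen on an aromatic carbon, para to a large group. Among the compounds with values here, the one measured step that bears on this change is an at least 5.2-fold lower number from compound 1 to compound 2 (0.71 log units; beyond the scatter) for cyano in place of hydrogen on an aromatic carbon. That step involves a different group, so it offers only loose guidance, but a step of similar size towards lower numbers is expected. The estimated step is an at least 4.0-fold lower number from compound 1 to compound 3 (0.60 log units; beyond the scatter) in this assay on this reasoning. Compound 3 is expected at 2500 nM (estimated range 500 nM to 10000 nM)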

Compound 3, half-maximal inhibitory concentration: 5 nM
For compound 3 the middle estimate is 500-fold (2.70 log units) above the measured one; the measured number lies below the stated range.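

With 2-oxopyrrolidin-1-yl on an aromatic carbon, para to a large group, this assay shows an at least 2000-fold lower number from compound 1 to compound 3 (3.30 log units; beyond the scatter). The earlier step, an at least 5.2-fold lower number from compound 1 to compound 2 (0.71 log units; beyond the scatter), had shown that a nitrile on this aromatic ring can matter; the new step shows that a single replacement of hydrogen on the ring, here by a group of 6 heavy atoms, can take the shared core from a limit to a low number. Compound 1 has only a limit of the assay, so this step gives a bound and not an exact size: the limit of > 10000 nM in this assay, at which 1 of the 3 values shown sits.

What the compounds shown leave open is whether a plain pyrrolidin-1-yl, without the carbonyl, or an open-chain acetamide would give a similar number at this position. They also leave open how 2-oxopyrrolidin-1-yl would behave elsewhere on the aromatic ring.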